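The compounds below may be only part of what the source reports. "The series", "measured", "known", "first", "only" and "open" are said of these compounds alone.

Compound 3 `Cc1ccc(CC(COC(=O)C(C)(C)C)CN(O)/C(S)=N/Cc2ccc(NS(C)(=O)=O)c(F)c2)cc1C` holds the highest of the three numbers recorded in a functional assay on CHO cells for antagonist activity at transient receptor potential cation channel subfamily V member 1 (Rattus norvegicus); on this read-out lower numbers stand for stronger inhibition and higher numbers for weaker inhibition: in this assay compound 3 gives 94 nM. Compound 1 `Cc1ccc(CC(CN/C(S)=N/Cc2ccc(NS(C)(=O)=O)cc2)COC(=O)C(C)(C)C)cc1C` gives 67 nM, a gap to compound 3 that stays within the scatter, whereas compound 2 `Cc1ccc(CC(CNC(=S)NCc2ccc(NS(C)(=O)=O)c(F)c2)COC(=O)C(C)(C)C)cc1C` gives 7.8 nM, a gap that lies well beyond it. Compound 4 `CC(C)(C)C(=O)OCC(Cc1ccc(C(C)(C)C)cc1)CN(O)/C(S)=N/Cc1ccc(NS(C)(=O)=O)c(F)c1` has not yet been measured in this assay; it differs from compound 3 in one place: 4-(tert-butyl)phenyl in place of 3,4-dimethylphenyl on a saturated chain carbon, three bonds along the chain from an amine nitrogen and an oxygen next to a carbonyl group. Among the compounds with values here, no measured pair shows this exchange, so nothing in the recorded numbers sets its size. A small step at most, not clearly beyond the scatter, is the reasonable expectation in this assay. Compound 4 is therefore expected to give about 60 nM, estimated to fall between 20 nM and 200 nM. That amounts to an expected step of a 1.6-fold lower number from compound 3 to compound 4 (0.19 log units; within the scatter).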

Compound 4, half-maximal inhibitory concentration: 10100 nM
Estimate against measurement, compound 4: 170-fold (2.23 log units) below; the measured number lies above the stated range.
By their numbers in this assay, from the lowest: compound 2; then compounds 1 and 3 (each within the scatter of the next); then compound 4.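

In this assay, replacing 3,4-dimethylphenyl with 4-(tert-butyl)phenyl on this saturated chain carbon gives a 110-fold higher number from compound 3 to compound 4 (2.03 log units; beyond the scatter), showing that the read-out at this position is highly sensitive to the aryl substituents. The two groups share one six-membered aromatic ring of carbon only, and neither has hydrogen-bond donors or acceptors, yet the exchange is large. Nothing measured here explains the step. The compounds shown leave open whether the loss follows from adding the tert-butyl group or from removing the 3-methyl group. They also leave open how an unsubstituted phenyl or a cyclohexyl group would read at this position.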